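Substituent swap on the saturated ring carbon of compound 3

The source may report more compounds than this note shows. Statements on the series, on what has been measured and on what is new or still open speak of the compounds shown alone.

Measured compounds:
Compound 1 `C[C@@H]1COC(c2cccc(OC(=O)NC3CCCCC3)c2)=N1` gives 16 nM in an assay (strain Wistar) for inhibition of Fatty-acid amide hydrolase 1 (Rattus norvegicus), read by scintillation counting; a higher number here means a weaker inhibitor, a lower number a stronger inhibitor.
Compound 2 `O=C(NC1CCCCC1)Oc1cccc(C2=N[C@@H](Cc3ccccc3)CO2)c1` gives 2100 nM in this assay.
Compound 3 `O=C(NC1CCCCC1)Oc1cccc(C2=N[C@H](Cc3ccccc3)CO2)c1` gives 590 nM in this assay.

Compound 3 stands second highest of the three numbers. Its nearest neighbour is compound 2: a 3.6-fold lower number from compound 2 to compound 3 (0.55 log units; beyond the scatter), a step that rests only on (the fact that compounds 2 and 3 differ only in the configuration as drawn). The furthest is compound 1: a 37-fold higher number from compound 1 to compound 3 (1.57 log units; beyond the scatter), so the benzyl group on the saturated ring carbon costs a large amount against the methyl of compound 1.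

Compound 4 `COC(=O)[C@@H]1COC(c2cccc(OC(=O)NC3CCCCC3)c2)=N1` differs from compound 3 as follows: methoxycarbonyl in place of benzyl on a saturated ring carbon. Going by the values given here, the step that bears on this position is a 37-fold higher number from compound 1 to compound 3 (1.57 log units; beyond the scatter), the only one in which the group on that carbon changes; the configuration step from compound 2 to compound 3 is modest and compound 4 keeps the configuration drawn for compound 3. The entering group is smaller than benzyl by the counts given, so a lower number in this assay is expected, part of the way back toward compound 1 but without a measured precedent for this group. Compound 4 is therefore estimated at 150 nM, with a range from 30 nM to 800 nM, meaning an expected step of a 3.9-fold lower number from compound 3 to compound 4 (0.59 log units; beyond the scatter).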

Compound 4, half-maximal inhibitory concentration: 9.4 nM
For compound 4 the middle estimate is 16-fold (1.20 log units) above the measured one; the whole stated range lies above it.
By their numbers in this assay, from the lowest: compounds 4 and 1 (each within the scatter of the next); then compound 3; then compound 2.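

In this assay the saturated ring carbon accepts more than the methyl of compound 1: methoxycarbonyl in place of methyl gives no change beyond the scatter (a 1.7-fold lower number from compound 1 to compound 4 (0.23 log units; within the scatter)). The loss seen with benzyl is therefore not shared by every group beyond methyl at this carbon, and methoxycarbonyl in place of benzyl recovers it in full (a 63-fold lower number from compound 3 to compound 4 (1.80 log units; beyond the scatter)). Nothing measured here gives a cause for either step.

The compounds shown do not separate the removal of the aromatic ring, the two hydrogen-bond acceptors and the heavy-atom count of the entering group as the source of the recovery. Also open, on these data alone, are a carboxylic acid, a hydroxymethyl or an ethyl ester on this carbon, and the opposite drawn configuration of compound 4.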